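Chloro for Methyl on the Outer Phenyl of Compound 3

The source may report more compounds than this note shows. Statements on the series, on what has been measured and on what is new or still open speak of the compounds shown alone.

Measured so far:
compound 1 `Cc1ccc(-n2cc(-c3ccccc3NS(=O)(=O)c3c[nH]c(=O)[nH]c3=O)nn2)cc1` with 2190 nM
compound 2 `O=c1[nH]cc(S(=O)(=O)Nc2ccccc2-c2cn(-c3ccc(Cl)cc3)nn2)c(=O)[nH]1` with 1750 nM
compound 3 `Cc1cccc(-n2cc(-c3cccc(NS(=O)(=O)c4c[nH]c(=O)[nH]c4=O)c3)nn2)c1` with 4080 nM

In a functional assay on OVCAR-3 cells (Homo sapiens) for antiproliferative activity, read by MTT assay, with a stated time of 24 h (on this read-out higher numbers stand for weaker inhibition and lower numbers for stronger inhibition), compound 3 gives the highest of the three numbers. Its nearest neighbour is compound 1, whose number in this assay is lower, though the gap between the two lies within the scatter; compound 2 stands further off, and that gap lies beyond the scatter.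

The step to compound 4 `O=c1[nH]cc(S(=O)(=O)Nc2cccc(-c3cn(-c4cccc(Cl)c4)nn3)c2)c(=O)[nH]1` consists of chloro in place of methyl on an aromatic carbon. Among the compounds with values here, one measured step bears on it directly: a 1.3-fold lower number from compound 1 to compound 2 (0.10 log units; within the scatter), the same exchange on the same ring of the shared core, differing from the present case only in where the group sits on that ring. That step stayed within the scatter.

On this basis one expects no shift beyond the scatter in this assay for compound 4, with at most a slight move toward a lower number, as a 1.2-fold lower number from compound 3 to compound 4 (0.09 log units; within the scatter) expresses. Compound 4 is accordingly estimated at 3300 nM, with a range from 1600 nM to 6800 nM. Within the data shown here, since only one such exchange has been measured, the range is kept wide.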

Compound 4, half-maximal inhibitory concentration: 3410 nM
Compound 4: the middle estimate sits 1.0-fold (0.01 log units) below what was measured; the measured number falls inside the stated range.
By their numbers in this assay, from the lowest: compounds 2, 1, 4 and 3 (each within the scatter of the next, the first and the last beyond it).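

In this assay, the exchange of 3-methylphenyl for 3-chlorophenyl gives a 1.2-fold lower number from compound 3 to compound 4 (0.08 log units; within the scatter), which shows that chloro in place of methyl at this place, meta to a large group, does not move the number beyond the scatter. Within the data shown here, until this result, the exchange had been read on only one core; it can now be read on two, and the two steps agree: the same change on two cores in this assay, a 1.3-fold lower number (0.10 log units; within the scatter) from compound 1 to compound 2 and a 1.2-fold lower number (0.08 log units; within the scatter) from compound 3 to compound 4, 1.0-fold (0.02 log units) apart, within the scatter of two such steps. Within the compounds shown, chloro and methyl on the outer phenyl can therefore be exchanged on either core without a shift beyond the scatter, a statement that holds for these two pairs and these two groups only.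

As far as these compounds go, it remains open whether a different group at this place, such as methoxy, an amine or a carboxylic acid, would shift the number in this assay beyond the scatter, and whether a phenyl carrying no group at all would do so. From the compounds shown here alone, the effect of where the group sits on the outer phenyl also remains open, since compound 1 and compound 3 differ in more than one place, as do compound 2 and compound 4.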